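A few compounds are considered here, and "the series" means these few. Any claim that something is new, unique, unknown or untested is made for them only; others in the source may bear on it.

Of the compounds shown here, two built on the same core have been measured. Compound 1 `N/C(=N\CCC(c1ccc(O)cc1)c1ccccn1)NCCCc1c[nH]cn1` reaches 1 in a functional assay on cardiac atrium for agonist activity at histamine H2 receptor (Cavia porcellus); a lower number here means a smaller maximal response, a higher number a larger maximal response. Compound 2 `N=C(NCCCc1c[nH]cn1)NCCC(c1cccc(C(F)(F)F)c1)c1ccccn1` reaches 1 in this assay, which is level with compound 1 within the usual scatter of this kind of measurement. Compound 3 `N=C(NCCCc1c[nH]cn1)NCCC(c1ccccn1)c1ccccn1` is the next compound in line; it differs from compound 2 in one place: pyridin-2-yl in place of 3-(trifluoromethyl)phenyl on a saturated chain carbon bound to an aromatic carbon and a saturated chain carbon. Since compound 2 already gives a full maximal response, the step from compound 2 to compound 3 is expected to stay within the scatter, with no change in either direction no change at the digits printed from compound 2 to compound 3 (within the scatter). Compound 3 is therefore expected to reach 1 in this assay, most likely between 0.85 and 1.05.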

Compound 3, intrinsic activity: the largest response reached, as a fraction of the reference agonist's: 1
Estimate against measurement, compound 3: no gap at the digits printed; measured number inside the range.
By their numbers in this assay, from the lowest: compounds 1, 2 and 3 (each within the scatter of the next).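

In this assay the swap of 3-(trifluoromethyl)phenyl for pyridin-2-yl on this saturated chain carbon gives no change at the digits printed from compound 2 to compound 3 (within the scatter) on this read-out. This position therefore accepts a ring with a hetero atom and fewer heavy atoms, and the trifluoromethyl group is not needed to keep this maximal response. No measurement here explains the result. The read-out reports only the largest response, not the concentration needed to reach it. From the compounds shown here alone, whether a carboxylic acid or a saturated cyclohexyl ring at this place would keep the response stays open.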